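A few compounds are considered here, and "the series" means these few. Any claim that something is new, unique, unknown or untested is made for them only; others in the source may bear on it.

The measured compounds:

Compound 1, `C[C@]1(O)C[C@@](c2cccc(C(F)(F)F)c2)([C@H](O)c2ccccn2)C1`, gives 300 nM.
Compound 2, `C[C@]1(O)C[C@@](c2ccc(C(F)(F)F)cc2)([C@H](O)c2ccccn2)C1`, gives 840 nM.
Compound 3, `C[C@]1(O)C[C@@](c2ccc(OC(F)(F)F)cc2)([C@H](O)c2ccccn2)C1`, gives 330 nM.

All three were tested in an assay on HEK293 cells for antagonist activity at transient receptor potential cation channel subfamily V member 3 (Homo sapiens), read by FLIPR and calcium flux; a lower number here means a stronger inhibitor, a higher number a weaker inhibitor. Compound 1 and compound 2 are built from the same atoms joined differently; the difference between the two cores is not broken down here. Their values show that compound 1 gives the lower number, by a margin beyond the scatter, whereas the numbers for compound 1 and compound 3 lie within the scatter of each other.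

Between compound 2 and compound 3 there is one change, (trifluoromethoxy in place of trifluoromethyl on an aromatic carbon). This change gave a 2.5-fold lower number from compound 2 to compound 3 (0.41 log units; beyond the scatter).

Compound 4, `C[C@]1(O)C[C@@](c2cccc(OC(F)(F)F)c2)([C@H](O)c2ccccn2)C1`, has not yet been measured in this assay. Relative to compound 1 it carries the change (trifluoromethoxy in place of trifluoromethyl on an aromatic carbon). The place differs from the earlier case: in compound 3 the new group sits para to a large group, in compound 4 it sits meta to a large group, so this is the same kind of change rather than the same change.

Resting on the earlier step of a 2.5-fold lower number from compound 2 to compound 3 (0.41 log units; beyond the scatter), a step of similar direction is expected from compound 1, and it is estimated as a 2.0-fold lower number from compound 1 to compound 4 (0.30 log units; within the scatter). Compound 4 is therefore expected to give about 150 nM in this assay, estimated to fall between 60 nM and 400 nM.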

Compound 4, antagonist equilibrium constant: 280 nM
Beside the measured number, compound 4's estimate is 1.9-fold (0.27 log units) below it; low and high end bracket the measured number.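

In this assay, trifluoromethoxy in place of trifluoromethyl on the core of compound 1, where the group sits meta to a large group, gave a 1.1-fold lower number from compound 1 to compound 4 (0.03 log units; within the scatter). The same change on the other core had moved the number further, yet the two steps cannot be told apart: the same change on two cores in this assay, a 2.5-fold lower number (0.41 log units; beyond the scatter) from compound 2 to compound 3 and a 1.1-fold lower number (0.03 log units; within the scatter) from compound 1 to compound 4, 2.4-fold (0.38 log units) apart, within the scatter of two such steps. For the compounds shown here, this shows that the results are compatible with a single effect of this change on both cores, and that no step in the opposite direction beyond the scatter appeared, but it does not show that the gain seen on one core reliably carries to the other, since only one of the two steps lies beyond the scatter and two pairs are too few to settle whether the place of the group matters.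

Every compound shown carries either trifluoromethyl or trifluoromethoxy on the aromatic ring, so it remains open how a nitrile, a methoxy group or a chlorine atom would read there in this assay. On these data alone, it is also open whether the same change would behave alike if an amine stood in place of either hydroxyl group of the shared core.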